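This account rests on a few compounds, and the source may have more. Where it says the series, first, only, none or still open, it means among the compounds named here.

In an assay on HEK293 cells for negative allosteric modulation of metabotropic glutamate receptor 5 (Homo sapiens), read by FLIPR, with a stated time of 1 h (a lower number here means a stronger inhibitor, a higher number a weaker inhibitor), compound 1 `CCN1CCc2nc(C#Cc3ccccc3)sc2C1` gives 1200 nM and compound 2 `CC(C)CN1CCc2nc(C#Cc3ccccc3)sc2C1` gives 650 nM; the step of a 1.8-fold lower number from compound 1 to compound 2 (0.27 log units; within the scatter) puts an isopropyl in place of a methyl on the saturated chain carbon bound to the ring amine nitrogen. Compound 3 `CC1CC(C(=O)N2CCc3nc(C#Cc4ccccc4)sc3C2)C1` gives > 10000 nM in this assay, which is a limit of the assay and not a number. Compound 3 thus stands apart from the other two, the only one of the three sitting at the limit of > 10000 nM in this assay, at which 1 of the 3 values shown sits. The steps of an at least 8.3-fold higher number from compound 1 to compound 3 (0.92 log units; beyond the scatter) and an at least 15-fold higher number from compound 2 to compound 3 (1.18 log units; beyond the scatter) both replace an alkyl group on the ring amine nitrogen by the (3-methylcyclobutyl)carbonyl group, and both go beyond the scatter.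

Compound 4 `O=C(C1CC(F)C1)N1CCc2nc(C#Cc3ccccc3)sc2C1` differs from compound 3 by fluoro in place of methyl on a saturated ring carbon. Within the data shown here, none of the measured steps touches this position: they all bear on the group carried by the nitrogen, not on the four-membered ring within that group. The expected step is a step that the limit leaves unreadable from compound 3 to compound 4, none beyond the scatter. Compound 4 is therefore expected to give 15000 nM in this assay, between 5000 nM and 50000 nM, most likely again reported only as a limit.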

Compound 4, half-maximal inhibitory concentration: > 10000 nM
Compound 4: only a limit was reported; the forecaster's own chance of this, stated with the estimate: 70%; the middle value lies beyond the limit too.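

In this assay compound 4 gives > 10000 nM, a limit of the assay and not a number. Replacing the alkyl group on the ring amine nitrogen with (3-fluorocyclobutyl)carbonyl gives an at least 8.3-fold higher number from compound 1 to compound 4 (0.92 log units; beyond the scatter) and an at least 15-fold higher number from compound 2 to compound 4 (1.18 log units; beyond the scatter), so the loss seen with compound 3 does not depend on the methyl on the four-membered ring. The step from compound 3 to compound 4 cannot be read, so any difference between fluoro and methyl on this saturated ring carbon stays hidden, with both compounds at the same limit: the limit of > 10000 nM in this assay, at which 2 of the 4 values shown sit.

The compounds shown leave open whether a hydroxyl or an amine on this ring carbon would give a readable value. They also leave open whether the carbonyl or the cyclobutyl part matters more, which a cyclobutylmethyl group on the nitrogen could test.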